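The source may report more compounds than this note shows. Statements on the series, on what has been measured and on what is new or still open speak of the compounds shown alone.

Within the data shown here, compound 1 `CCCn1c(-c2ccccc2)nc2c(NC3CCOC3)ncnc21` gives 9080 nM in a functional assay on CHO cells for antagonist activity at adenosine receptor A2b (Homo sapiens), read by 33P incorporation, with a stated time of 20 min (on this read-out higher numbers stand for weaker inhibition and lower numbers for stronger inhibition), the higher of the two numbers so far; its neighbour, compound 2 `CCCn1c(-c2ccccc2)nc2c(NC3CCCCC3)ncnc21`, gives 5310 nM, and the step of a 1.7-fold lower number from compound 1 to compound 2 (0.23 log units; within the scatter) concerns the group on the nitrogen of the shared core, not the chain examined here. Compound 3 `Cn1c(-c2ccccc2)nc2c(NC3CCOC3)ncnc21` differs from compound 1 by hydrogen in place of ethyl on a saturated chain carbon bound to an aromatic nitrogen. No measured step touches this chain, so no direction is supported by the numbers shown; the expected outcome for compound 3 is set wide around its parent, an estimated 1.7-fold higher number from compound 1 to compound 3 (0.22 log units; within the scatter), giving an expected 15000 nM within 5000 nM to 45000 nM.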

Compound 3, inhibition constant: 13300 nM
The estimate for compound 3 lay 1.1-fold (0.05 log units) above the measured number, within the range that was stated.
By their numbers in this assay, from the lowest: compounds 2, 1 and 3 (each within the scatter of the next, the first and the last beyond it).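

Replacing ethyl with hydrogen on a saturated chain carbon bound to an aromatic nitrogen, which turns propyl into methyl, gives a 1.5-fold higher number from compound 1 to compound 3 (0.17 log units; within the scatter) in this assay. This first measured change to the chain therefore shows that, for this pair, the shorter chain cannot be told apart from the longer one. No available evidence bears on this result.

From the compounds shown here alone, whether a longer chain such as butyl, or an amine or carboxylic acid in place of propyl, would move the number beyond the scatter remains open. So does whether methyl would behave alike alongside the cyclohexyl group of compound 2.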